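Phenyl on the ring nitrogen: estimate for compound 3

The source may report more compounds than this note shows. Statements on the series, on what has been measured and on what is new or still open speak of the compounds shown alone.

Measured compounds
- compound 1, `Nc1c(C(=O)c2ccccc2)sc(Nc2ccccc2)c1-c1nnc(NC(=O)c2ccccc2)o1`: 101 ug/mL
- compound 2, `Nc1n[nH]c(Nc2ccccc2)c1-c1nnc(NC(=O)c2ccccc2)o1`: 38.3 ug/mL

In a functional assay on MCF7 cells (Homo sapiens) for cytotoxicity, read by MTT assay, with a stated time of 96 h (a higher number here means a weaker inhibitor, a lower number a stronger inhibitor), compound 1 gives 101 ug/mL, and compound 2 gives 38.3 ug/mL. Compound 2 holds the lower of the two numbers; the gap to compound 1 lies beyond the scatter. For the measured compounds named here, the two compounds differ in more than one place, so no single structural step is read from that pair.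

Compound 3, `Nc1nn(-c2ccccc2)c(Nc2ccccc2)c1-c1nnc(NC(=O)c2ccccc2)o1`, differs from compound 2 in phenyl in place of hydrogen on an aromatic nitrogen. Going by the values given here, no step of this kind exists among the measured compounds, so the size of the change is not anchored. In the absence of such a step, the expected step of a 1.1-fold lower number from compound 2 to compound 3 (0.04 log units; within the scatter) is taken to be within the scatter, with a wide range allowed in either direction. Compound 3 is therefore expected to give 35 ug/mL in this assay, estimated between 12 ug/mL and 100 ug/mL.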

Compound 3, half-maximal inhibitory concentration: 99.1 ug/mL
Beside the measured number, compound 3's estimate is 2.8-fold (0.45 log units) below it, and the stated range covers the measured number.
By their numbers in this assay, from the lowest: compound 2; then compounds 3 and 1 (each within the scatter of the next).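

In this assay, for the compounds shown here, the ring nitrogen gives the first readable step: phenyl in place of hydrogen on this aromatic nitrogen gives a 2.6-fold higher number from compound 2 to compound 3 (0.41 log units; beyond the scatter). The step is modest but beyond the scatter, so this position is not indifferent to substitution, and this change moves the number towards weaker inhibition. Nothing available accounts for the step, and it remains a bare observation from one pair of compounds.

From the compounds shown here alone, whether a methyl or an aminoethyl chain on the same nitrogen would stay closer to the number of compound 2 remains open, so it cannot yet be said whether the shift is particular to phenyl. Also open, going by these compounds, is whether a phenyl carrying a carboxylic acid or a methoxy group at this position would shift the number further or recover it.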